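Moving the trifluoromethyl group: expectation for compound 3

The source may report more compounds than this note shows. Statements on the series, on what has been measured and on what is new or still open speak of the compounds shown alone.

Measured so far:
compound 1 `COc1cc2cc(Oc3ccc(NC(=O)Nc4ccccc4)cc3)c(C)nc2cc1OC` — in a functional assay on NCI-H226 cells (Homo sapiens) for inhibition, read by sulforhodamine B assay, with a stated time of 48 h, tested at 10 uM (a higher number here means a weaker effect of the compound at the concentration tested, a lower number a stronger effect), compound 1 gives 39.8%
compound 2 `COc1cc2cc(Oc3ccc(NC(=O)Nc4ccc(C(F)(F)F)cc4)cc3)c(C)nc2cc1OC` — in this assay compound 2 gives 20.9%

Compound 2 stands lowest of the two numbers in this assay; its nearest neighbour is compound 1, and the step of a number 18.9 percentage points lower from compound 1 to compound 2 (beyond the scatter) lies beyond the scatter. For the measured compounds named here, that is the only measured step.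

Compound 3 `COc1cc2cc(Oc3ccc(NC(=O)Nc4cccc(C(F)(F)F)c4)cc3)c(C)nc2cc1OC` is not yet measured in this assay. Compared with compound 2 the change is 3-(trifluoromethyl)phenyl in place of 4-(trifluoromethyl)phenyl on an amide-type nitrogen — the same atoms, joined differently.

Going by the values given here, no measured step compares two placements of the trifluoromethyl group; the step from compound 1 to compound 2 concerns the presence of the group, not where it sits. There is therefore no measured basis for a shift in either direction, and the step of a number 5.1 percentage points higher from compound 2 to compound 3 (within the scatter) is expected to stay within the scatter, with the range widened to allow for the absence of a direct precedent. Compound 3 is estimated at 26% in this assay, between 10% and 46%.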

Compound 3, a percentage reported as activity, at one concentration (the size of the read-out at that concentration, not a potency): -23.5%
Compound 3: the middle estimate sits 49.5 percentage points above what was measured; measured number outside the range, below it.
By their numbers in this assay, from the lowest: compound 3; then compound 2; then compound 1.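

In this assay, the position of the trifluoromethyl group on the terminal phenyl ring matters as much as its presence: 3-(trifluoromethyl)phenyl in place of 4-(trifluoromethyl)phenyl on the same amide-type nitrogen gives a number 44.4 percentage points lower from compound 2 to compound 3 (beyond the scatter) with no change in atom count, which the earlier pair could not show. Against the unsubstituted phenyl, the same group gives a number 63.3 percentage points lower from compound 1 to compound 3 (beyond the scatter) in this placement, a larger step than a number 18.9 percentage points lower from compound 1 to compound 2 (beyond the scatter) for the 4-(trifluoromethyl)phenyl compound, so the gain from adding trifluoromethyl here depends on where it sits. No measurement available on these compounds explains why the two placements part so widely.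

Still open, going by these compounds, is whether the effect belongs to the trifluoromethyl group itself or to any group at this placement, which a chlorine, a methoxy or a nitrile on the same ring would test. Each read-out comes from a single concentration. The order of compound 2 and compound 3 describes a stronger or weaker effect at that concentration only, and a full concentration series on both would show how the two compare at other concentrations.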